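Moving the hydroxyphenyl substituent across two related cores

A few compounds are considered here, and "the series" means these few. Any claim that something is new, unique, unknown or untested is made for them only; others in the source may bear on it.

Compound 1 `Oc1cccc(-c2cc(-c3ccc(F)cc3)cc(-c3ccccc3O)n2)c1` and compound 2 `Oc1cccc(-c2cc(-c3ccc(F)cc3)cc(-c3cccc(O)c3)n2)c1` differ by 3-hydroxyphenyl in place of 2-hydroxyphenyl on an aromatic carbon. In a functional assay on T47D cells (Homo sapiens) for inhibition (on this read-out higher numbers stand for weaker inhibition and lower numbers for stronger inhibition), compound 1 reaches only a limit, > 50000 nM. In this assay compound 2 gives 6870 nM. The resulting step is an at least 7.2-fold lower number from compound 1 to compound 2 (0.86 log units; beyond the scatter); it is itself only a bound because the limit of > 50000 nM in this assay, at which 1 of the 3 values shown sits, marks where compound 1 sits. Compound 3 `Oc1cccc(-c2cc(-c3ccccc3OC(F)(F)F)cc(-c3ccccc3O)n2)c1` carries a different core; how the two cores differ is not broken down here. In this assay compound 3 gives 2680 nM. Compound 4 `Oc1cccc(-c2cc(-c3ccccc3OC(F)(F)F)cc(-c3cccc(O)c3)n2)c1` is not yet measured and differs from compound 3 by 3-hydroxyphenyl in place of 2-hydroxyphenyl on an aromatic carbon. This is the same kind of change as from compound 1 to compound 2, though the place differs: there the position is meta to a 4-fluorophenyl group, here meta to a large group. Beside an at least 7.2-fold lower number from compound 1 to compound 2 (0.86 log units; beyond the scatter), compound 4 is expected to show a 5.4-fold lower number from compound 3 to compound 4 (0.73 log units; beyond the scatter), resting on compound 3 at 2680 nM and the earlier gain. The estimate for compound 4 in this assay is 500 nM, between 120 nM and 2000 nM.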

Compound 4, half-maximal inhibitory concentration: 7950 nM
For compound 4 the middle estimate is 16-fold (1.20 log units) below the measured one; measured number outside the range, above it.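

In this assay the new step is a 3.0-fold higher number from compound 3 to compound 4 (0.47 log units; beyond the scatter), so replacing 2-hydroxyphenyl with 3-hydroxyphenyl runs the opposite way on the core of compound 3. Beside the earlier step, the change does not carry over between these two cores: the same change on two cores in this assay, an at least 7.2-fold lower number (0.86 log units; beyond the scatter) from compound 1 to compound 2 and a 3.0-fold higher number (0.47 log units; beyond the scatter) from compound 3 to compound 4, at least 21-fold (1.33 log units) apart, beyond the scatter of two such steps. Two pairs do not show what in the cores reverses the step, and the earlier step remains only a bound, with compound 1 standing at a limit: the limit of > 50000 nM in this assay, at which 1 of the 4 values shown sits.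

Still open, from the compounds shown here alone, is whether the reversal extends to any further core. Going by these compounds, it is also open whether an amine or a carboxylic acid in place of the hydroxyl on that ring would follow either direction.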